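Metabolic stability of a nitro-substituted series: compound 3 to compound 4

A few compounds are considered here, and "the series" means these few. Any claim that something is new, unique, unknown or untested is made for them only; others in the source may bear on it.

Measured compounds:
compound 1, `Nc1cc(C(F)(F)F)cc2c(=O)cc(N3CCN(CC4CCCCC4)CC3)sc12` — 0.9%
compound 2, `O=C(OC1CCC(CN2CCN(c3cc(=O)c4cc(C(F)(F)F)cc([N+](=O)[O-])c4s3)CC2)CC1)c1ccco1` — 1%
compound 3, `CC(=O)NC1CCC(CN2CCN(c3cc(=O)c4cc(C(F)(F)F)cc([N+](=O)[O-])c4s3)CC2)CC1` — 86.8%

In an ADME assay on cells (Hepatocyte, Homo sapiens) for metabolic stability, with a stated time of 30 min (a lower number here means that less of the compound is left, a higher number that more of the compound is left), compound 3 stands highest of the three numbers. Its nearest neighbour is compound 2, which gives 1%, and furthest from it is compound 1, which gives 0.9%; both gaps lie beyond the scatter. Within the data shown here, the only single-point step among the measured compounds is a number 85.8 percentage points higher from compound 2 to compound 3 (beyond the scatter), where an acetamido replaces a ((furan-2-yl)carbonyl)oxy on a saturated ring carbon.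

Compound 4, `O=c1cc(N2CCN(CC3CCC(NS(=O)(=O)c4ccccc4)CC3)CC2)sc2c([N+](=O)[O-])cc(C(F)(F)F)cc12`, has not yet been measured. It differs from compound 3 by phenylsulfonyl in place of acetyl on an amine nitrogen. Among the measured compounds shown here, no measured step involves a phenylsulfonyl group, so nothing bears directly on this change. What the step of a number 85.8 percentage points higher from compound 2 to compound 3 (beyond the scatter) does show is that the group attached at this saturated ring carbon can move the number across almost the whole range of the scale, so a large step in either direction cannot be excluded for compound 4.

Taking compound 3 as the starting point, the account expects a downward step a number 46.8 percentage points lower from compound 3 to compound 4 (beyond the scatter) for compound 4, with wide uncertainty. The estimate for compound 4 is 40%, in a range from 5% to 85%.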

Compound 4, percent of the compound remaining: 90.8%
Compound 4: middle estimate off by 50.8 percentage points, on the low side; measured number outside the range, above it.
By their numbers in this assay, from the lowest: compounds 1 and 2 (each within the scatter of the next); then compounds 3 and 4 (each within the scatter of the next).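

In this assay, putting phenylsulfonyl in place of acetyl on the amine nitrogen gives a number 4 percentage points higher from compound 3 to compound 4 (within the scatter), so a group that brings in an aromatic ring of carbon and more heavy atoms cannot be told apart from acetyl here. The replacement of ((furan-2-yl)carbonyl)oxy on the saturated ring carbon by (phenylsulfonyl)amino gives a number 89.8 percentage points higher from compound 2 to compound 4 (beyond the scatter), and together with a number 85.8 percentage points higher from compound 2 to compound 3 (beyond the scatter) this shows that the large step is not tied to acetamido alone, as two different groups on this amine nitrogen both stand well apart from compound 2. Nothing available explains why the two groups on nitrogen read alike or why compound 2 stands apart from them.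

The compounds shown leave open whether the step depends on the nitrogen at the saturated ring carbon or on the loss of the furan, which a (furan-2-yl)carbonyl group on the same amine nitrogen, or a plain amine or hydroxyl at that carbon, would bear on. They also leave open whether the nitro group of compounds 2, 3 and 4 plays any part, since compound 1 differs from them in more than one place and an amine in its place on the core of compound 4 would be needed to separate the two.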